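Double bond geometry at the exocyclic alkene of compound 3

The source may report more compounds than this note shows. Statements on the series, on what has been measured and on what is new or still open speak of the compounds shown alone.

Measured compounds:
compound 1, `O=C(O)COC/C=C1\C[C@H]2C[C@@H](O)[C@H](/C=N/NC(=O)Nc3ccc(Cl)c(Cl)c3)[C@H]2C1`: 180 nM
compound 2, `O=C(O)CCC/C=C1\C[C@H]2C[C@@H](O)[C@H](/C=N/NC(=O)Nc3ccc([N+](=O)[O-])cc3)[C@H]2C1`: 60 nM
compound 3, `O=C(O)COC/C=C1/C[C@H]2C[C@@H](O)[C@H](/C=N/NC(=O)Nc3ccc([N+](=O)[O-])cc3)[C@H]2C1`: 20 nM

In a functional assay on a cell-free system (plasma) for agonist activity at thromboxane A2 receptor (Homo sapiens) (on this read-out lower numbers stand for stronger inhibition and higher numbers for weaker inhibition), compound 3 gives the lowest number of the three. Compound 2 stands at a higher number, with the gap beyond the scatter, and compound 1 is furthest away, also beyond the scatter.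

Compound 4, `O=C(O)COC/C=C1\C[C@H]2C[C@@H](O)[C@H](/C=N/NC(=O)Nc3ccc([N+](=O)[O-])cc3)[C@H]2C1`, has not yet been measured. Its relation to compound 3: the two compounds have the same atoms and bonds and differ only in configuration as drawn: 1 of 6 stereo elements differ; a double bond is drawn Z in compound 3 and E in compound 4. Within the data shown here, no pair of measured compounds differs in this way alone, so the size of this step is not known from the data here. The expected step from compound 3 to compound 4 is a 2.0-fold higher number from compound 3 to compound 4 (0.30 log units; within the scatter), a modest weakening that may not exceed the scatter. Compound 4 is expected to give about 40 nM, within 10 nM to 160 nM.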

Compound 4, half-maximal inhibitory concentration: 190 nM
The estimate for compound 4 lay 4.8-fold (0.68 log units) below the measured number; the whole stated range lies below it.
By their numbers in this assay, from the lowest: compound 3; then compound 2; then compounds 1 and 4 (each within the scatter of the next).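

In this assay, the geometry of the exocyclic double bond alone carries a 9.5-fold higher number from compound 3 to compound 4 (0.98 log units; beyond the scatter), because nothing else separates the pair: the fact that compounds 3 and 4 differ only in the configuration as drawn. With the double bond drawn E, carboxymethoxy in place of 2-carboxyethyl gives a 3.2-fold higher number from compound 2 to compound 4 (0.50 log units; beyond the scatter), so the chain change also registers. In the same geometry, 4-nitrophenyl in place of 3,4-dichlorophenyl gives a 1.1-fold higher number from compound 1 to compound 4 (0.02 log units; within the scatter), which does not separate the two aryl groups. From the compounds shown here alone, whether Z geometry brings a similar step with the 2-carboxyethyl chain or with 3,4-dichlorophenyl remains open. So does the effect of a primary amide in place of the carboxylic acid.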